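Working notes: compound 4 against compounds 1 to 3

The source may hold more compounds than are shown below. What is called first, only, known or untested is meant among the compounds shown, and "the series" means these compounds.

Compound 1, `CCCCCCCCC1CC(=O)N(c2ccccc2C(=O)OCC2CCCN(CCCc3ccccc3)C2)C1=O`, compound 2, `CC(C)C1CC(=O)N(c2ccccc2C(=O)OCC2CCCN(CCCc3ccccc3)C2)C1=O`, and compound 3, `O=C(OCC1CCCN(CCCc2ccccc2)C1)c1ccccc1N1C(=O)CC(Cc2ccccc2)C1=O`, share one core and differ only in the group carried on a saturated ring carbon. In a functional assay with Neuronal acetylcholine receptor; alpha3/beta4 (Homo sapiens) as the target (on this read-out higher numbers stand for weaker inhibition and lower numbers for stronger inhibition), compound 1 gives 1300 nM, compound 2 gives 2500 nM and compound 3 gives 1300 nM. Compound 2 shows the highest of the three numbers, yet its distances to the others are small: a 1.9-fold higher number from compound 1 to compound 2 (0.28 log units; within the scatter) and a 1.9-fold lower number from compound 2 to compound 3 (0.28 log units; within the scatter), and likewise no change at the digits printed from compound 1 to compound 3 (within the scatter). All three measured steps thus fall within the scatter, and all of them concern only the substituent on that saturated ring carbon.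

Compound 4, `O=C(OCC1CCCN(CCCc2ccccc2)C1)c1ccccc1C(F)(F)F`, is a change of a different kind: a group of 4 heavy atoms (1 carbon, 3 fluorine; no ring) in place of a group of 10 heavy atoms (7 carbon, 1 nitrogen, 2 oxygen; one five-membered non-aromatic ring with 1 hetero atom), on an aromatic carbon. Among the measured compounds shown here, no measured step removes this ring or touches the aromatic carbon it sits on, so the three steps bear on compound 4 only indirectly; they show that varying the group on the five-membered ring leaves this assay unmoved, but say nothing about taking the ring away. The expected step is set as a 1.6-fold higher number from compound 2 to compound 4 (0.20 log units; within the scatter), toward a modestly higher number, with a wide range. The estimate for compound 4 in this assay is 4000 nM, between 1000 nM and 16000 nM.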

Compound 4, half-maximal inhibitory concentration: 3200 nM
Compound 4: middle estimate off by 1.3-fold (0.10 log units), on the high side; measured number inside the range.
By their numbers in this assay, from the lowest: compounds 1, 3, 2 and 4 (each within the scatter of the next, the first and the last beyond it).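

In this assay, trifluoromethyl in place of the whole group carrying the five-membered non-aromatic ring, on the aromatic carbon ortho to a large group, gives a 1.3-fold higher number from compound 2 to compound 4 (0.11 log units; within the scatter). Among the compounds shown here, this aromatic carbon was untouched by the earlier steps, and the new step shows that the ring, with its 2 hydrogen-bond acceptors, can leave it without a step beyond the scatter from compound 2, so inhibition does not depend on that ring being present; measured against compound 1 at 1300 nM, however, compound 4 at 3200 nM lies beyond the scatter, so the reading depends on which ring-bearing compound serves as the reference. No data at hand account for the size of this step.

How a chlorine, a methoxy group or a plain hydrogen on that aromatic carbon would read in this assay remains open, as the compounds shown hold only trifluoromethyl and the ring-bearing group there. Also open, going by these compounds, is whether a benzyl group or a longer chain in place of the phenylpropyl chain would read differently with trifluoromethyl kept.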